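Expecting Little Movement From Compound 2 to Compound 3

The source may report more compounds than this note shows. Statements on the series, on what has been measured and on what is new or still open speak of the compounds shown alone.

In a functional assay on DU-145 cells (Homo sapiens) for inhibition, read by MTT assay, with a stated time of 48 h (on this read-out higher numbers stand for weaker inhibition and lower numbers for stronger inhibition), compound 1 `Cc1ccc(OCc2cn(-c3ccc(NS(C)(=O)=O)c(Oc4ccccc4)c3)nn2)cc1` gives 8200 nM and compound 2 `Cc1ccc(-c2cn(-c3ccc(NS(C)(=O)=O)c(Oc4ccccc4)c3)nn2)cc1` gives 11200 nM. Going by the values given here, compound 2 thus stands within the usual scatter of the only other number available.

Compound 3 `CS(=O)(=O)Nc1ccc(-n2cc(COc3ccc(Cl)cc3)nn2)cc1Oc1ccccc1` has not yet been measured. It departs from compound 2 by a single change: (4-chlorophenoxy)methyl in place of 4-methylphenyl on an aromatic carbon. In words, (4-chlorophenoxy)methyl takes the place of 4-methylphenyl on an aromatic carbon of a five-membered aromatic ring with 3 nitrogen.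

Among the compounds with values here, one measured step bears on this: a 1.4-fold higher number from compound 1 to compound 2 (0.14 log units; within the scatter). It came with 4-methylphenyl in place of (4-methylphenoxy)methyl, so it nearly mirrors the new change. Within the data shown here, the new group differs from the one in compound 1 by carrying chloro where that group carries methyl, and no measured compound shows what this swap does on its own. A step beyond the scatter is therefore not expected in this assay. The estimated step is a 1.4-fold lower number from compound 2 to compound 3 (0.15 log units; within the scatter). The expected value for compound 3 is 8000 nM, with an expected range of 3500 nM to 18000 nM.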

Compound 3, half-maximal inhibitory concentration: 6400 nM
Estimate against measurement, compound 3: 1.3-fold (0.10 log units) above, within the range that was stated.
By their numbers in this assay, from the lowest: compounds 3, 1 and 2 (each within the scatter of the next).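

In this assay, the exchange at this aromatic carbon of the five-membered ring has now been read a second time: (4-chlorophenoxy)methyl in place of 4-methylphenyl gives a 1.8-fold lower number from compound 2 to compound 3 (0.24 log units; within the scatter), so a side group with an oxygen-linked methylene and a group with its aromatic ring attached directly again cannot be told apart. The result also gives the first reading of chloro in place of methyl on the aromatic ring of the side group, a 1.3-fold lower number from compound 1 to compound 3 (0.11 log units; within the scatter), so neither kind of change moves the number beyond the scatter among these three compounds. Nothing available explains these small steps or ties them to any property of the groups.

Going by these compounds, all three groups at this position carry a six-membered aromatic ring of carbon only, so the effect of an amine, a carboxylic acid or a longer chain without such a ring remains open. Also open, on these data alone, is whether fluoro or methoxy in place of chloro, on the same side group, would produce a step that rises beyond the scatter.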